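A few compounds are considered here, and "the series" means these few. Any claim that something is new, unique, unknown or untested is made for them only; others in the source may bear on it.

Measured in an ADME assay on MT4 cells (Homo sapiens) for cytotoxicity; on this read-out lower numbers stand for higher toxicity in this test and higher numbers for lower toxicity in this test:

compound 1 `CCc1c(Cc2ccccc2Br)nc(SCC(=O)c2ccc(OC)cc2)[nH]c1=O`: 187000 nM
compound 2 `CCc1c(Cc2cccc(Br)c2)nc(SCC(=O)c2ccc(OC)cc2)[nH]c1=O`: 142000 nM
compound 3 `CCc1c(Cc2ccc(Br)cc2)nc(SCC(=O)c2ccc(OC)cc2)[nH]c1=O`: a limit of the assay, > 264000 nM

Compound 3 sits at the limit of > 264000 nM in this assay, at which 1 of the 3 values shown sits; its value is a limit, not a number. The measured steps are a 1.3-fold lower number from compound 1 to compound 2 (0.12 log units; within the scatter), an at least 1.4-fold higher number from compound 1 to compound 3 (0.14 log units; that floor lies within the scatter) and an at least 1.8-fold higher number from compound 2 to compound 3 (0.26 log units; that floor lies within the scatter), none of them beyond the scatter. Compound 4 `CCc1c(Cc2cc(C)cc(C)c2)nc(SCC(=O)c2ccc(OC)cc2)[nH]c1=O` differs from compound 3 by 3,5-dimethylphenyl in place of 4-bromophenyl on a saturated chain carbon bound to an aromatic carbon. Among the compounds with values here, no measured step covers this change; the three bromophenyl placements all leave the numbers close together. The step of an at least 1.3-fold lower number from compound 3 to compound 4 (0.12 log units; that floor lies within the scatter) is therefore expected to stay within the scatter, with no clear direction. For compound 4 the estimate in this assay is 200000 nM, expected between 100000 nM and 400000 nM, and a limit rather than a number is again possible.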

Compound 4, half-maximal cytotoxic concentration: >= 239000 nM
Compound 4 ended at the assay's limit; the forecaster's own chance of this, stated with the estimate: 40%; middle value at least 1.1-fold (0.07 log units) from the limit.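

In this assay compound 4 ends at a limit and not at a number: the limit of >= 239000 nM in this assay, at which 1 of the 4 values shown sits.
At this place, on a saturated chain carbon bound to an aromatic carbon, 3,5-dimethylphenyl carries no bromine, yet the readable steps, an at least 1.6-fold higher number from compound 2 to compound 4 (0.22 log units; that floor lies within the scatter) and an at least 1.2-fold higher number from compound 1 to compound 4 (0.10 log units; that floor lies within the scatter), both stay within the scatter at their floors. The step between compound 3 and compound 4 cannot be read.

Open, as far as these compounds go, is whether an amine or a carboxylic acid in place of the methyl groups would keep the numbers in this range. Also open, from the compounds shown here alone, are the numbers behind the limits of compound 3 and compound 4.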